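Adding a Methyl to a Ring Amine in a Nicotinic Series

The source may report more compounds than this note shows. Statements on the series, on what has been measured and on what is new or still open speak of the compounds shown alone.

Of the compounds shown here, three have been measured in an in vitro assay on SH-EP1 cells for displacement of a labelled ligand from Neuronal acetylcholine receptor; alpha4/beta2 (Homo sapiens); on this read-out higher numbers stand for weaker inhibition and lower numbers for stronger inhibition. Compound 3 `COc1cc(C2=CC3CNCC(C2)C3)cnc1Cl` gives 0.4 nM. Compound 1 `COc1cc(C2=CC3CC(C2)CN(C)C3)cnc1Cl` differs from it in a single place: methyl in place of hydrogen on an amine nitrogen in a ring. In this assay compound 1 gives 4.4 nM. That change made a large step, an 11-fold higher number from compound 3 to compound 1 (1.04 log units; beyond the scatter). Compound 2 `C1=C(c2cccnc2)C[C@@H]2CNC[C@H]1C2` is built on another core; the difference between its core and the core of compound 3 is not broken down here. In this assay compound 2 gives 0.1 nM, the lowest of the three numbers and beyond the scatter from both of the others.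

Compound 4 `CN1C[C@@H]2C=C(c3cccnc3)C[C@@H](C2)C1` has not yet been measured. It is related to compound 2 by the same change seen between compound 3 and compound 1: methyl in place of hydrogen on an amine nitrogen in a ring. The place described for both changes is the same word for word, so the two are the same change, made on different cores. Among the compounds shown it occurs twice in all, and only one instance has numbers on both sides.

The expectation therefore rests on a single pair. Because an 11-fold higher number from compound 3 to compound 1 (1.04 log units; beyond the scatter) was large and beyond the scatter, compound 4 is expected to sit higher by a step of about an 11-fold higher number from compound 2 to compound 4 (1.04 log units; beyond the scatter), with the added uncertainty of carrying one observation onto a different core. Compound 4 is thus estimated at 1.1 nM, most likely between 0.35 nM and 3.5 nM.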

Compound 4, inhibition constant: 9.4 nM
Estimate against measurement, compound 4: 8.5-fold (0.93 log units) below; the measured number lies above the stated range.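

Putting methyl in place of hydrogen on an amine nitrogen in a ring raised the number on both cores in this assay, and the new instance is a 94-fold higher number from compound 2 to compound 4 (1.97 log units; beyond the scatter), so the direction of the change carried from one core to the other and binding became weaker both times. The size of the step did not carry over, and the gap between the two steps is larger than repeated measurements would be expected to produce: the same change on two cores in this assay, an 11-fold higher number (1.04 log units; beyond the scatter) from compound 3 to compound 1 and a 94-fold higher number (1.97 log units; beyond the scatter) from compound 2 to compound 4, 8.5-fold (0.93 log units) apart, beyond the scatter of two such steps. This shows that, in this series, the direction of this change is a better guide than its size, but it rests on just two pairs of compounds and does not show which difference between the cores goes with the larger step, or why the steps differ.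

The compounds shown leave open what a larger group on the same nitrogen, such as ethyl or a longer chain, would do to the number on either core. From the compounds shown here alone, they also leave open how the step would behave on further cores, so it remains unknown whether a typical size for this change exists at all or whether it must be measured afresh on each core.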